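The compounds below may be only part of what the source reports. "The series", "measured", "known", "first", "only" and "open" are said of these compounds alone.

Measured so far in a functional assay on HOP-92 cells (Homo sapiens) for cytotoxicity, read by sulforhodamine B assay, with a stated time of 48 h; on this read-out higher numbers stand for lower toxicity in this test and lower numbers for higher toxicity in this test:

- compound 1, `ClCc1cccc(Cn2cnc3c(Cl)nc(Cl)nc32)c1`: 7080 nM
- compound 2, `Nc1nc(Cl)c2ncn(Cc3ccccc3CCl)c2n1`: a limit only, > 100000 nM
- compound 3, `ClCc1ccccc1Cn1cnc2ncnc(Cl)c21`: 51300 nM

Of the two values that are actual numbers in this assay, compound 1 has the lower one and compound 3 the higher, and the gap between the two is wider than the usual scatter of repeated measurements. Compound 2 reached no number at all; the assay reports only (the limit of > 100000 nM in this assay, at which 1 of the 3 values shown sits).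

Compound 4, `Nc1nc(Cl)c2ncn(Cc3cccc(CCl)c3)c2n1`, has not yet been tested in this assay. It is compound 1 with one change: amino in place of chloro on an aromatic carbon. Among the measured compounds shown here, the only hint in the measured set is that the one compound carrying an amino group at that kind of position, compound 2, stopped at a limit, while compound 1 and compound 3, which do not, gave numbers. On that basis the step is expected to go toward a higher number, that is, lower toxicity, and to be larger than the scatter: a 5.6-fold higher number from compound 1 to compound 4 (0.75 log units; beyond the scatter) is the estimate. Compound 4 is accordingly expected to come in near 40000 nM in this assay, plausibly anywhere from 12000 nM to 120000 nM, with a real chance that it too ends as a limit rather than a number.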

Compound 4, concentration lethal to 50% of the cells: > 100000 nM
Compound 4 was reported as a limit; the forecaster's own chance of this, stated with the estimate: 30%; at least 2.5-fold (0.39 log units) between middle value and limit.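

In this assay, among the compounds shown here, this is the first comparison in which only the group on this aromatic carbon, between two ring nitrogen atoms, changes, and putting amino in place of chloro gives an at least 14-fold higher number from compound 1 to compound 4 (1.14 log units; beyond the scatter). Compound 4 gives > 100000 nM, which is a limit of the assay and not a number, so the printed step is a minimum and its full size cannot be read. Compound 2, the other compound with amino on this kind of carbon, stands at the same limit, and so no amino compound shown has yet given an actual number: the limit of > 100000 nM in this assay, at which 2 of the 4 values shown sit.

The compounds shown leave open whether the loss of toxicity in this test is specific to amino or would also follow from other replacements for chloro, such as a methylamine, a hydroxyl or a methoxy group. They also leave open whether any such group would give an actual number lying between that of compound 1 and the limit, which would show how much change this position can tolerate.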